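Sulfur in Place of Selenium and Cytotoxicity on Colon Cells

The source may report more compounds than this note shows. Statements on the series, on what has been measured and on what is new or still open speak of the compounds shown alone.

Measured compounds:
compound 1 `CS/C(=N\C(=O)c1cc(-c2ccccc2)nc2ccccc12)NC(=O)c1cc(-c2ccccc2)nc2ccccc12`: > 100000 nM
compound 2 `C[Se]/C(=N\C(=O)c1cc(-c2ccccc2)nc2ccccc12)NC(=O)c1cc(-c2ccccc2)nc2ccccc12`: 90700 nM
compound 3 `C[Se]/C(=N\C(=O)c1cnc2ccccc2c1)NC(=O)c1cnc2ccccc2c1`: > 100000 nM

All three were tested in a functional assay on HT-29 cells (Homo sapiens) for cytotoxicity, read by MTT assay, with a stated time of 72 h; on this read-out lower numbers stand for higher toxicity in this test and higher numbers for lower toxicity in this test. Compound 2 gives 90700 nM. Compound 1 gives > 100000 nM, which is a limit of the assay and not a number. Compound 3 gives > 100000 nM, again a limit. From compound 2 to compound 1 the change is a group of 2 heavy atoms (1 carbon, 1 sulfur; no ring) in place of a group of 2 heavy atoms (1 carbon, 1 selenium; no ring), on a carbon with a double bond to nitrogen, and the step is an at least 1.1-fold higher number from compound 2 to compound 1 (0.04 log units; that floor lies within the scatter). Compound 3 and compound 2 carry different cores; the difference between the two cores is not broken down here. Compound 4 `CS/C(=N\C(=O)c1cnc2ccccc2c1)NC(=O)c1cnc2ccccc2c1` is not yet measured and differs from compound 3 by a group of 2 heavy atoms (1 carbon, 1 sulfur; no ring) in place of a group of 2 heavy atoms (1 carbon, 1 selenium; no ring), on a carbon with a double bond to nitrogen, the same change at the same place. The step that the limit leaves unreadable from compound 3 to compound 4 is expected to resemble an at least 1.1-fold higher number from compound 2 to compound 1 (0.04 log units; that floor lies within the scatter), since the limit of > 100000 nM in this assay, at which 2 of the 3 values shown sit, already bounds compound 3. Compound 4 is therefore expected near 150000 nM, between 80000 nM and 600000 nM.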

Compound 4, concentration lethal to 50% of the cells: > 100000 nM
Compound 4: no number, only a limit; the forecaster's own chance of this, stated with the estimate: 90%; the middle value does not contradict the limit.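

In this assay no step can be read between compound 3 and compound 4, as each gives only a limit of the assay: the limit of > 100000 nM in this assay, at which 3 of the 4 values shown sit.

The compounds shown leave open whether methylsulfanyl in place of the selenium-bearing group changes the toxicity of compound 3 at all.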